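From compound 2 to compound 3: a much smaller group

The source may hold more compounds than are shown below. What is called first, only, known or untested is meant among the compounds shown, and "the series" means these compounds.

Compound 1 `O=Cc1ccc(COc2ccc(OCCOCCNC3CCCC3)cc2)cc1`: 45000 nM
Compound 2 `COC(=O)c1ccccc1COc1ccc(OCCOCCNC2CCCC2)cc1`: > 100000 nM (a limit)

Both entries come from a functional assay on SK-OV-3 cells (Homo sapiens) for inhibition, read by CCK-8 assay, with a stated time of 70 h; a higher number here means a weaker inhibitor, a lower number a stronger inhibitor. Compound 2 is known only as a limit: it sits at the limit of > 100000 nM in this assay, at which 1 of the 2 values shown sits. Compound 3 `CCOc1ccc(OCCOCCNC2CCCC2)cc1` changes the same place: methyl in place of 2-(methoxycarbonyl)phenyl on a saturated chain carbon bound to an oxygen on an aromatic ring. Among the measured compounds shown here, the one measured step that bears on this is an at least 2.2-fold higher number from compound 1 to compound 2 (0.34 log units; beyond the scatter), a change of group at this place that lies beyond the scatter and is modest in size. It gives no measured size for removing the aromatic ring, and the limit fixes no starting number. For the measured compounds named here, the only number at this place remains that of compound 1 at 45000 nM, so a modest move toward a lower number is expected. Compound 3 may also stay at the limit of compound 2. The expected step is an at least 1.6-fold lower number from compound 2 to compound 3 (0.22 log units; that floor lies within the scatter). For compound 3 the estimated value in this assay is 60000 nM, with an expected range of 20000 nM to 150000 nM.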

Compound 3, half-maximal inhibitory concentration: 90500 nM
Estimate against measurement, compound 3: 1.5-fold (0.18 log units) below; the measured number falls inside the stated range.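

In this assay, methyl in place of 4-formylphenyl gives a 2.0-fold higher number from compound 1 to compound 3 (0.30 log units; within the scatter), so at this place, on a saturated chain carbon bound to an oxygen on an aromatic ring, the loss of the aromatic ring of compound 1 brings no change that can be told from the scatter. Methyl in place of 2-(methoxycarbonyl)phenyl gives an at least 1.1-fold lower number from compound 2 to compound 3 (0.04 log units; that floor lies within the scatter), so this step has only a floor and its true size stays unknown. The entry for compound 2 is a limit and not a number: the limit of > 100000 nM in this assay, at which 1 of the 3 values shown sits.

As far as these compounds go, whether an amine or a carboxylic acid on the aromatic ring, or a longer chain in place of methyl, would give a much lower number stays open. Also open, from the compounds shown here alone, is whether 4-formylphenyl and 2-(methoxycarbonyl)phenyl part through the group itself or through its placing on the ring, as the two names differ in both.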